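The source may hold more compounds than are shown below. What is called first, only, known or untested is meant among the compounds shown, and "the series" means these compounds.

Among the measured compounds shown here, compound 2 `COc1ccc(-n2nc(C(=O)Nc3ccc(Oc4ccnc5cc(OCCCN6CCCCC6)c(OC)cc45)c(F)c3)c(C)cc2=O)cc1` stands highest of the two numbers so far in a functional assay on HT-29 cells (Homo sapiens) for inhibition, read by MTT assay, with a stated time of 72 h (a lower number here means a stronger inhibitor, a higher number a weaker inhibitor), where compound 2 gives 3200 nM. For the measured compounds named here, its only neighbour, compound 1 `COc1cc2c(Oc3ccc(NC(=O)c4nn(-c5ccccc5C(F)(F)F)c(=O)cc4C)cc3F)ccnc2cc1OCCCN1CCCCC1`, gives 170 nM in this assay; the single step between them, a 19-fold higher number from compound 1 to compound 2 (1.27 log units; beyond the scatter), came with 4-methoxyphenyl in place of 2-(trifluoromethyl)phenyl on an aromatic nitrogen. Compound 3 `COc1cc2c(Oc3ccc(NC(=O)c4nn(-c5ccc(Cl)cc5)c(=O)cc4C)cc3F)ccnc2cc1OCCCN1CCCCC1` is compound 2 with chloro in place of methoxy on an aromatic carbon. Going by the values given here, no measured step swaps one group for another on this phenyl ring, so the bearing of the data is indirect: a 19-fold higher number from compound 1 to compound 2 (1.27 log units; beyond the scatter) shows that what sits on this ring can shift the number strongly, but it does not tell which way chloro will go. Compound 3 is therefore expected to land at 1000 nM, with a wide range from 300 nM to 3500 nM. For compound 3 that estimate means a 3.2-fold lower number from compound 2 to compound 3 (0.51 log units; beyond the scatter), a modest expected gain that the scatter and the lack of a direct comparison leave uncertain.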

Compound 3, half-maximal inhibitory concentration: 360 nM
Compound 3: middle estimate off by 2.8-fold (0.44 log units), on the high side; low and high end bracket the measured number.
By their numbers in this assay, from the lowest: compound 1; then compound 3; then compound 2.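

In this assay, among the compounds shown here, the change from 4-methoxyphenyl to 4-chlorophenyl gives an 8.9-fold lower number from compound 2 to compound 3 (0.95 log units; beyond the scatter) and is the first direct swap of one group for another at this place on the ring, para to a large group. It shows that this one substituent alone can move the number beyond the scatter. The other step, a 2.1-fold higher number from compound 1 to compound 3 (0.33 log units; beyond the scatter) and itself beyond the scatter, leaves compound 3 much nearer to compound 1 than compound 2 stands, and nothing shown here explains the effect of the chloro group.

Whether the lower number depends on chloro or simply on the loss of methoxy stays open, since no compound shown carries fluoro, methyl or hydrogen at this place. A 4-(trifluoromethyl)phenyl would also be needed to tell whether the edge of compound 1 lies with the trifluoromethyl group or with where it sits.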